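A Methyl Leaves an Aromatic Oxygen in Two Settings

A few compounds are considered here, and "the series" means these few. Any claim that something is new, unique, unknown or untested is made for them only; others in the source may bear on it.

Of the compounds shown here, three have been measured here. Compound 1 is `COc1ccc(C(=O)NNC(=O)/C=C/c2ccc(O)cc2)cc1`. Compound 2 is `O=C(/C=C/c1ccc(O)cc1)NNC(=O)c1ccc(O)cc1`. Compound 3 is `COc1ccc(C(=O)NNC(=O)/C=C/c2cc(OC)c(O)c(OC)c2)cc1`. All three were tested in an ADME assay on NL20 cells (Homo sapiens) for antiproliferative activity, read by MTT assay, with a stated time of 24 h; a higher number here means a weaker inhibitor, a lower number a stronger inhibitor.

In this assay compound 1 gives only a limit, > 10000 nM, not a number. Compound 2 gives 8620 nM. The change between them is hydrogen in place of methyl on an oxygen on an aromatic ring, and it made an at least 1.1-fold lower number from compound 1 to compound 2 (0.06 log units; that floor lies within the scatter). Because one of the values is the limit of > 10000 nM in this assay, at which 1 of the 3 values shown sits, the true size of that step is not pinned down.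

Compound 3 gives 9420 nM. Its value and that of compound 2 lie within the usual scatter of each other, so nothing can be read into which is larger. The difference between the core of compound 1 and the core of compound 3 is not broken down here.

Compound 4, `COc1cc(/C=C/C(=O)NNC(=O)c2ccc(O)cc2)cc(OC)c1O`, has not yet been measured. It differs from compound 3 by hydrogen in place of methyl on an oxygen on an aromatic ring, the same change, in the same kind of place, as that from compound 1 to compound 2. Given that the measured step from compound 1 to compound 2 reached only an at least 1.1-fold lower number from compound 1 to compound 2 (0.06 log units; that floor lies within the scatter), the step from compound 3 to compound 4 is expected to be a 1.1-fold lower number from compound 3 to compound 4 (0.04 log units; within the scatter), that is, small. On that basis the value of compound 4 in this assay is estimated at 8500 nM, most likely falling between 4500 nM and 16000 nM.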

Compound 4, half-maximal inhibitory concentration: > 10000 nM
Compound 4: a limit, no number; the forecaster's own chance of this, stated with the estimate: 25%; middle value at least 1.1-fold (0.07 log units) away from the limit.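

In this assay compound 4 gives > 10000 nM, which is a limit and not a number. Putting hydrogen in place of methyl on the oxygen on the aromatic ring of this second core gives an at least 1.0-fold higher number from compound 3 to compound 4 (0.02 log units; that floor lies within the scatter), and the comparison with the first core cannot separate the two results: the same change on two cores in this assay, an at least 1.1-fold lower number (0.06 log units; that floor lies within the scatter) from compound 1 to compound 2 and an at least 1.0-fold higher number (0.02 log units; that floor lies within the scatter) from compound 3 to compound 4; the limit leaves it open whether they differ. On these data alone, the floors of the two steps point in opposite directions, but both lie within the scatter and the true sizes remain unknown, so the data show neither that the change carries over from one core to another nor that it behaves differently on each, and the reading is restricted by a shared ceiling: the limit of > 10000 nM in this assay, at which 2 of the 4 values shown sit.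

The compounds shown leave open what this change does on a core where both partners give a real number in this assay, since only such a pair could give a step of known size. They also leave open what would happen with a different group in the same place, such as an ethoxy group with its longer chain or an amine in place of the oxygen.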